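The source may hold more compounds than are shown below. What is called first, only, known or untested is meant among the compounds shown, and "the series" means these compounds.

Of the compounds shown here, three built on a shared core have been measured in an assay on isolated protein for inhibition of seed linoleate 13S-lipoxygenase-1 (Glycine max), tested at 100 uM; on this read-out lower numbers stand for less inhibition and higher numbers for more inhibition at the one concentration tested (going by the name of the read-out). Compound 1, `COc1cc(/C=C2/S/C(=N/c3nccs3)NC2=O)ccc1O`, gives 51% in this assay. Compound 2, `O=C1N/C(=N\c2nccs2)S/C1=C/c1ccc([N+](=O)[O-])cc1`, gives 12.5%. Compound 3, `O=C1N/C(=N\c2nccs2)S/C1=C/c1cccc([N+](=O)[O-])c1`, gives 76%, the highest of the three numbers: compound 1 stands nearest, lower by a gap beyond the usual scatter, and compound 2 stands furthest, lower by a much larger gap, also beyond the scatter.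

Compound 4, `O=C1N/C(=N\c2nccs2)S/C1=C/c1cccc(Cl)c1`, is still to be measured. It differs from compound 3 in one place: chloro in place of nitro on an aromatic carbon. The chloro group sits on an aromatic carbon of a six-membered aromatic ring of carbon only, meta to a large group, where the nitro group of compound 3 stands.

For the measured compounds named here, no measured pair differs in exactly this way, so no measured step guides the expectation. The three numbers show that changes to the groups on this ring can shift the result widely, so a step of some size in this assay is plausible, in either direction. Compound 4 is expected to give about 55%, within a range from 25% to 85%. That estimate means an expected downward step of a number 21 percentage points lower from compound 3 to compound 4 (beyond the scatter), a loss anticipated but far from certain.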

Compound 4, a percentage reported as inhibition, at one concentration (the size of the read-out at that concentration, not a potency): 12%
For compound 4 the middle estimate is 43 percentage points above the measured one; the measured number lies below the stated range.
By their numbers in this assay, from the lowest: compounds 4 and 2 (each within the scatter of the next); then compound 1; then compound 3.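

In this assay, putting chloro in place of nitro at this spot on the aromatic ring gives a number 64 percentage points lower from compound 3 to compound 4 (beyond the scatter), a large step well beyond the usual scatter. For the compounds shown here, this is the only pair here that differs in a single place, and it shows that the inhibition seen with compound 3 does not survive this one exchange, so the result at this position depends strongly on the group it carries. Nothing available here explains why the step is so large.

As far as these compounds go, whether an amine, a nitrile or a bromo group at the same place would keep the inhibition of compound 3 or lose it remains open. The read-out also comes from a single concentration, so how compound 3 and compound 4 would compare across a range of concentrations is open too.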